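Ester-to-amide step on a thiazole anilide series

The compounds below may be only part of what the source reports. "The series", "measured", "known", "first", "only" and "open" are said of these compounds alone.

Compound 1 `CCOC(=O)c1sc(-c2cccc(NC(=O)c3ccccc3F)c2)nc1Nc1ccc(N2CCN(C)CC2)cc1`: 2000 nM in a functional assay on Ramos cells (Homo sapiens) for antiproliferative activity, read by CCK-8 assay, with a stated time of 72 h; on this read-out higher numbers stand for weaker inhibition and lower numbers for stronger inhibition
Compound 2 `CCOC(=O)c1sc(-c2cccc(NC(=O)c3ccc(Cl)cc3)c2)nc1Nc1ccc(N2CCN(C)CC2)cc1`: "not determined" (no result reported) in this assay

Going by the values given here, compound 2 stands as "not determined" (no result reported) in this assay, so it brings no number; the only value in the set belongs to compound 1, which gives 2000 nM. Among the compounds with values here, no pair of measured compounds differing in one place exists, so no measured step is available.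

Compound 3 `CN1CCN(c2ccc(Nc3nc(-c4cccc(NC(=O)c5ccc(Cl)cc5)c4)sc3C(N)=O)cc2)CC1` is the next compound to be tested. It differs from compound 2 in one place: amino in place of ethoxy on a carbonyl carbon. The rest of the molecule, including the chlorobenzamide and the methylpiperazinyl aniline, is unchanged.

With no measured step of this kind in the set, the size and direction of the change in this assay cannot be taken from data; the working expectation is a step no larger than the usual scatter, in either direction, with the only anchor being compound 1 at 2000 nM. For compound 3, the expected value in this assay is 1500 nM, with an estimated range from 300 nM to 8000 nM.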

Compound 3, half-maximal inhibitory concentration: 1360 nM
The estimate for compound 3 lay 1.1-fold (0.04 log units) above the measured number; measured number inside the range.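

Going by these compounds alone, compound 2 carries no number in this assay, so no step to compound 3 can be read. The compounds shown leave open what the change from ethoxycarbonyl to carbamoyl does to antiproliferative activity with the rest of the molecule held constant. No further data bear on the result of compound 3.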